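Pyridone in place of methoxypyridine on the enone ring

This account rests on a few compounds, and the source may have more. Where it says the series, first, only, none or still open, it means among the compounds named here.

Compound 1 `C[C@@H](O[C@H]1CN2C(=O)C=C(c3ccccc3)CC2[C@@H]1c1ccc(F)cc1)c1cc(C(F)(F)F)cc(C(F)(F)F)c1`: 89.5 nM
Compound 2 `C[C@@H](O[C@H]1CN2C(=O)C=C(c3cc[n+]([O-])cc3)CC2[C@@H]1c1ccc(F)cc1)c1cc(C(F)(F)F)cc(C(F)(F)F)c1`: 2.1 nM
Compound 3 `COc1cc(C2=CC(=O)N3C[C@H](O[C@H](C)c4cc(C(F)(F)F)cc(C(F)(F)F)c4)[C@@H](c4ccc(F)cc4)C3C2)ccn1`: 44 nM

In an assay on CHO cells for displacement of a labelled ligand from Substance-P receptor (Homo sapiens), in the presence of a further agent that is not named here (on this read-out lower numbers stand for stronger inhibition and higher numbers for weaker inhibition), compound 3 gives the second highest of the three numbers: compound 1 sits nearest, and compound 2 sits furthest below it. Compound 4 `C[C@@H](O[C@H]1CN2C(=O)C=C(c3cc[nH]c(=O)c3)CC2[C@@H]1c1ccc(F)cc1)c1cc(C(F)(F)F)cc(C(F)(F)F)c1` is not yet measured; its change from compound 3 is a group of 7 heavy atoms (5 carbon, 1 nitrogen, 1 oxygen; one six-membered aromatic ring with 1 hetero atom) in place of a group of 8 heavy atoms (6 carbon, 1 nitrogen, 1 oxygen; one six-membered aromatic ring with 1 hetero atom), on a double-bonded ring carbon. Steps at this position are large: a 43-fold lower number from compound 1 to compound 2 (1.63 log units; beyond the scatter) and a 21-fold higher number from compound 2 to compound 3 (1.32 log units; beyond the scatter), while a 2.0-fold lower number from compound 1 to compound 3 (0.31 log units; beyond the scatter) was modest. The new group shares a ring nitrogen and an oxygen with both compound 2 and compound 3, so a step below the scatter is expected for compound 4, estimated as a 3.7-fold lower number from compound 3 to compound 4 (0.56 log units; beyond the scatter). Compound 4 is therefore expected at 12 nM, with a range of 4 nM to 40 nM.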

Compound 4, half-maximal inhibitory concentration: 3.9 nM
Estimate against measurement, compound 4: 3.1-fold (0.49 log units) above, and the stated range ends above it.
By their numbers in this assay, from the lowest: compounds 2 and 4 (each within the scatter of the next); then compound 3; then compound 1.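

In this assay, putting the group of compound 4 in place of 2-methoxypyridin-4-yl gives an 11-fold lower number from compound 3 to compound 4 (1.05 log units; beyond the scatter), so rings carrying a nitrogen and an oxygen do not all behave alike on this double-bonded ring carbon. The step of a 1.9-fold higher number from compound 2 to compound 4 (0.27 log units; within the scatter) lies within the scatter, which leaves these two groups indistinguishable here, while a 23-fold lower number from compound 1 to compound 4 (1.36 log units; beyond the scatter) is a second large step away from phenyl at this position. Nothing given here bears on why these groups differ. From the compounds shown here alone, what a methyl group on the ring nitrogen of the new group, or a 2-aminopyridin-4-yl group on this carbon, would do remains open.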